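Trimming one methyl from the thiadiazole substituent

A few compounds are considered here, and "the series" means these few. Any claim that something is new, unique, unknown or untested is made for them only; others in the source may bear on it.

Measured compounds:
compound 1 `O=C(NCCC1CC1)c1ccc(N2CCC(Oc3ccccc3C(F)(F)F)CC2)nn1` — 14 nM
compound 2 `OCc1nnc(-c2ccc(N3CCC(Oc4ccccc4C(F)(F)F)CC3)nn2)s1` — 3.2 nM
compound 3 `CC(C)(C)c1nnc(-c2ccc(N3CCC(Oc4ccccc4C(F)(F)F)CC3)nn2)s1` — 710 nM

In an assay on microsomes from liver for inhibition of acyl-CoA desaturase 1 (Rattus norvegicus) (a higher number here means a weaker inhibitor, a lower number a stronger inhibitor), compound 3 gives the highest number of the three. The change a 51-fold higher number from compound 1 to compound 3 (1.71 log units; beyond the scatter) is large, and a 220-fold higher number from compound 2 to compound 3 (2.35 log units; beyond the scatter) is larger still, while a 4.4-fold lower number from compound 1 to compound 2 (0.64 log units; beyond the scatter) is modest. Compound 4 `CC(C)c1nnc(-c2ccc(N3CCC(Oc4ccccc4C(F)(F)F)CC3)nn2)s1` differs from compound 3 by hydrogen in place of methyl on a saturated chain carbon bound to an aromatic carbon and two saturated chain carbons. This change is not measured directly. Within the data shown here, the only step that bears on it is the one from compound 2 to compound 3, where a larger replacement at the same carbon of the thiadiazole gave a large rise; the step from compound 3 to compound 4 removes a single carbon, so it is taken as a smaller move in the opposite direction. Compound 4 is therefore expected to return part of the way toward the lower numbers, with an estimated step of a 2.8-fold lower number from compound 3 to compound 4 (0.45 log units; beyond the scatter), and the estimate for compound 4 in this assay is 250 nM, within a range from 80 nM to 900 nM.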

Compound 4, half-maximal inhibitory concentration: 8.8 nM
Compound 4: middle estimate off by 28-fold (1.45 log units), on the high side; measured number below the stated range.
By their numbers in this assay, from the lowest: compound 2; then compounds 4 and 1 (each within the scatter of the next); then compound 3.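

In this assay, among these compounds, removing one methyl, tert-butyl to isopropyl, gives an 81-fold lower number from compound 3 to compound 4 (1.91 log units; beyond the scatter), so most of the rise seen with tert-butyl on this thiadiazole carbon is tied to that single methyl, which the earlier compounds could not separate from the whole replacement of hydroxymethyl. The hydroxyl is also not required for a low number, since a 2.8-fold higher number from compound 2 to compound 4 (0.44 log units; beyond the scatter) is only a modest step, while a 1.6-fold lower number from compound 1 to compound 4 (0.20 log units; within the scatter) lies within the scatter, so the 5-isopropyl-1,3,4-thiadiazol-2-yl group matches the (2-cyclopropylethyl)carbamoyl group here. Nothing available explains the sharp change with this one methyl.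

The compounds shown leave open whether the rise is peculiar to tert-butyl or extends to other groups at this carbon. A cyclopropyl, an ethyl or an aminomethyl group there would help to settle this.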